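Urea aryl trifluoromethyl groups in the shared core series

The source may report more compounds than this note shows. Statements on the series, on what has been measured and on what is new or still open speak of the compounds shown alone.

Measured so far:
compound 1 `O=C(Nc1cccc(-n2cc(-c3ccncc3)c(-c3cc(O)cc(Cl)c3)n2)c1)Nc1ccc(Cl)c(C(F)(F)F)c1` gives 83% in a functional assay on UO-31 cells (Homo sapiens) for inhibition, read by sulforhodamine B assay, with a stated time of 48 h, tested at 0.1 uM; on this read-out higher numbers stand for a weaker effect at the one concentration tested and lower numbers for a stronger effect
compound 2 `O=C(Nc1cccc(-n2cc(-c3ccncc3)c(-c3cc(O)cc(Cl)c3)n2)c1)Nc1ccc(Cl)c(Cl)c1` gives 93% in this assay
compound 3 `COc1cc(Cl)cc(-c2nn(-c3cccc(NC(=O)Nc4cc(C(F)(F)F)cc(C(F)(F)F)c4)c3)cc2-c2ccncc2)c1` gives 75% in this assay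

Compound 3 has the lowest of the three numbers, but its nearest neighbour, compound 1, sits higher by an amount within the scatter; only compound 2 lies beyond the scatter from compound 3. Compound 3 therefore cannot be called the strongest of the set on these numbers alone. For the measured compounds named here, the single measured step, a number 10 percentage points higher from compound 1 to compound 2 (within the scatter), exchanges one aryl group on the urea for another and stays within the scatter.

Compound 4 `COc1cc(Cl)cc(-c2nn(-c3cccc(NC(=O)Nc4cccc(C(F)(F)F)c4)c3)cc2-c2ccncc2)c1` is not yet measured. It differs from compound 3 in one place: hydrogen in place of trifluoromethyl on an aromatic carbon. The ring keeps its other trifluoromethyl group, and the new hydrogen sits meta to it. Going by the values given here, no measured step removes a trifluoromethyl outright; the only step touching such a group replaces it with chloro and stays within the scatter. There is thus no basis for expecting a step beyond the scatter here, and the expected step from compound 3 to compound 4 is a number 5 percentage points higher from compound 3 to compound 4 (within the scatter). Compound 4 is accordingly estimated to give 80% in this assay, within a range from 66% to 94%.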

Compound 4, a percentage reported as activity, at one concentration (the size of the read-out at that concentration, not a potency): 50%
Beside the measured number, compound 4's estimate is 30 percentage points above it; measured number outside the range, below it.
By their numbers in this assay, from the lowest: compound 4; then compounds 3, 1 and 2 (each within the scatter of the next, the first and the last beyond it).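

In this assay, for the compounds shown here, hydrogen in place of trifluoromethyl on the urea aryl ring gives a number 25 percentage points lower from compound 3 to compound 4 (beyond the scatter), and this is the only step between compounds differing in one place that lies beyond the scatter; the chloro for trifluoromethyl exchange in a number 10 percentage points higher from compound 1 to compound 2 (within the scatter) did not show such a change. At this place, meta to a trifluoromethyl group, the second trifluoromethyl is therefore not needed for the effect at the one concentration tested, and the lower number of compound 4 stands for a stronger effect than that of compound 3. Nothing on hand bears on why this replacement moves the read-out by this amount.

What a nitrile, an amine or a carboxylic acid would give at this place remains open, since hydrogen is the only replacement shown here for the trifluoromethyl group on this core. Also open, on these data alone, are whether the remaining trifluoromethyl group of compound 4 contributes to the effect, and whether the same replacement would give a step of similar size on other urea aryl rings.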